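This account rests on a few compounds, and the source may have more. Where it says the series, first, only, none or still open, it means among the compounds named here.

Measured in a functional assay on SGC-7901 cells (Homo sapiens) for antiproliferative activity, read by MTT assay, with a stated time of 72 h; a lower number here means a stronger inhibitor, a higher number a weaker inhibitor:
- Compound 1 `COc1ccc(-c2ccc3ncn(-c4cc(OC)c(OC)c(OC)c4)c3c2)cc1F`: 430 nM
- Compound 2 `COc1cc(-n2cnc3ccc(-c4cc(F)ccc4F)cc32)cc(OC)c1OC`: 6590 nM
- Compound 3 `COc1cc(-n2cnc3ccc(-c4cccc(O)c4)cc32)cc(OC)c1OC`: 53 nM

Compound 3 has the lowest number of the three, shown by an 8.1-fold lower number from compound 1 to compound 3 (0.91 log units; beyond the scatter) and a 120-fold lower number from compound 2 to compound 3 (2.09 log units; beyond the scatter). Compound 4 `COc1cc(-n2cnc3ccc(-c4cccc([N+](=O)[O-])c4)cc32)cc(OC)c1OC` carries nitro in place of hydroxy on an aromatic carbon. Among the compounds with values here, no measured step makes this exact change. The two steps just given bear on it most closely, since each brings in 3-hydroxyphenyl and lowers the number, one modestly and one largely. Leaving 3-hydroxyphenyl is therefore expected to raise the number in this assay by a modest step, though the size is uncertain. The expected change is a 6.6-fold higher number from compound 3 to compound 4 (0.82 log units; beyond the scatter). For compound 4 the estimated value is 350 nM, with an expected range of 80 nM to 1800 nM.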

Compound 4, half-maximal inhibitory concentration: 380 nM
Estimate against measurement, compound 4: 1.1-fold (0.04 log units) below; low and high end bracket the measured number.
By their numbers in this assay, from the lowest: compound 3; then compounds 4 and 1 (each within the scatter of the next); then compound 2.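

On the aromatic carbon meta to a large group, the direct exchange of hydroxy for nitro in this assay gives a measured step (a 7.2-fold higher number from compound 3 to compound 4 (0.86 log units; beyond the scatter)), so this position does not hold its low number once hydroxy leaves. 3-Nitrophenyl remains clearly better than 2,5-difluorophenyl (a 17-fold lower number from compound 2 to compound 4 (1.24 log units; beyond the scatter)), yet it cannot be told apart from 3-fluoro-4-methoxyphenyl (a 1.1-fold lower number from compound 1 to compound 4 (0.05 log units; within the scatter)). Nothing available explains this difference between hydroxy and nitro. As far as these compounds go, whether an amine or a carboxylic acid at this position would stay near compound 3 remains open.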